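Saturating the Linker: From Phenylethynyl to Phenethyl

The source may hold more compounds than are shown below. What is called first, only, known or untested is meant among the compounds shown, and "the series" means these compounds.

Two amides built on a shared core have been tested in a functional assay on NIH3T3 cells for agonist activity at Urotensin-2 receptor (Homo sapiens), with a stated time of 5 days; on this read-out lower numbers stand for smaller maximal responses and higher numbers for larger maximal responses. Compound 1 `CN(C)CCC(NC(=O)CCc1ccc(C(F)(F)F)cc1)c1ccc2ccccc2c1` gives 75% in this assay. Compound 2 `CN(C)CCC(NC(=O)C#Cc1ccccc1)c1ccc2ccccc2c1` reaches 115% in this assay, the higher of the two numbers, and its gap to compound 1 lies beyond the usual scatter of such measurements. Compound 3 `CN(C)CCC(NC(=O)CCc1ccccc1)c1ccc2ccccc2c1` has not yet been measured. It differs from compound 2 in one place: phenethyl in place of 2-phenylethynyl on a carbonyl carbon. A downward step is expected, because compound 1, which also carries a phenethyl group on its carbonyl carbon, gives only 75% in this assay. The estimated step of a number 25 percentage points lower from compound 2 to compound 3 (beyond the scatter) would carry the response part of the way back toward that lower value. Compound 3 is therefore expected to give about 90% in this assay, with a range from 60% to 120%.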

Compound 3, largest response reached (reported as efficacy), in percent of the reference or control that the assay uses: 107%
The estimate for compound 3 lay 17 percentage points below the measured number, and the stated range covers the measured number.
By their numbers in this assay, from the lowest: compound 1; then compounds 3 and 2 (each within the scatter of the next).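

In this assay the change to phenethyl in place of 2-phenylethynyl on a carbonyl carbon gives a number 8 percentage points lower from compound 2 to compound 3 (within the scatter) and so leaves the response unchanged within the scatter, which means this position tolerates losing the triple bond. The lower response of compound 1 therefore does not go with the phenethyl group itself: hydrogen in place of trifluoromethyl on an aromatic carbon gives a number 32 percentage points higher from compound 1 to compound 3 (beyond the scatter) in this assay and marks the trifluoromethyl group as the feature that separates these two compounds. No measurement here explains why either change has the size it has.

The compounds shown do not tell whether a chlorine or a methoxy group on that aromatic carbon would lower the response as trifluoromethyl does. They also leave open how a longer chain on the carbonyl carbon, such as 3-phenylpropyl, would behave.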